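Compound 3: from methoxy to hydroxy

The compounds below may be only part of what the source reports. "The series", "measured", "known", "first", "only" and "open" are said of these compounds alone.

Compound 1 `COc1ccc(C(=O)NNC(=O)/C=C/c2ccc(O)cc2)cc1`: > 10000 nM (a limit)
Compound 2 `COc1cc(/C=C/C(=O)NNC(=O)c2ccccc2)ccc1O`: 9550 nM
Compound 3 `COc1ccc(C(=O)NNC(=O)/C=C/c2ccc(O)c(OC)c2)cc1`: > 10000 nM (a limit)

In an ADME assay on NL20 cells (Homo sapiens) for antiproliferative activity, read by MTT assay, with a stated time of 24 h (on this read-out lower numbers stand for stronger inhibition and higher numbers for weaker inhibition), compound 3 gives only a limit, > 10000 nM, and no number. This is the limit of > 10000 nM in this assay, at which 2 of the 3 values shown sit. Compound 4 `COc1ccc(C(=O)NNC(=O)/C=C/c2ccc(O)c(O)c2)cc1` differs from it by one change: hydrogen in place of methyl on an oxygen on an aromatic ring. The nearest measured steps are a different change, methoxy in place of hydrogen on an aromatic carbon. They read a step that the two limits leave unreadable from compound 1 to compound 3 and an at least 1.0-fold higher number from compound 2 to compound 3 (0.01 log units; that floor lies within the scatter). Neither shows a shift beyond the scatter, so no clear move is expected in this assay. The expected step is an at least 1.1-fold lower number from compound 3 to compound 4 (0.04 log units; that floor lies within the scatter). The estimate for compound 4 is 9000 nM, with an expected range from 4000 nM to 20000 nM.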

Compound 4, half-maximal inhibitory concentration: 9390 nM
Estimate against measurement, compound 4: 1.0-fold (0.02 log units) below; low and high end bracket the measured number.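

Replacing the methyl with hydrogen on this oxygen gives an at least 1.0-fold lower number from compound 3 to compound 4 (0.02 log units; that floor lies within the scatter), and adding hydroxy to the aromatic carbon gives an at least 1.0-fold lower number from compound 1 to compound 4 (0.02 log units; that floor lies within the scatter). Compound 4 thus gives this position a measured number in this assay, with a free hydroxy on the ring, but neither floor shows a shift beyond the scatter. The true size of both steps stays unknown because compound 1 and compound 3 each carry only a limit: the limit of > 10000 nM in this assay, at which 2 of the 4 values shown sit.

As far as these compounds go, whether an amine or a carboxylic acid at this place, or a longer chain on the oxygen, would move the number stays open.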